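The source may report more compounds than this note shows. Statements on the series, on what has been measured and on what is new or still open speak of the compounds shown alone.

Measured compounds:
- Compound 1 `Cc1ccc(Nc2nc(Cl)nc3c2ncn3Cc2ccc(/C=C/C(=O)Nc3ccccc3N)cc2)cc1` gives 51.3%
- Compound 2 `Nc1ccccc1NC(=O)c1ccc(CNc2nc(Cl)nc3c2ncn3Cc2ccccc2)cc1` gives 46.4%

Of the compounds shown here, two have been measured in a functional assay on NCI-H460 cells (Homo sapiens) for antiproliferative activity, read by CCK-8 assay, with a stated time of 72 h, tested at 8 uM; on this read-out higher numbers stand for a stronger effect at the one concentration tested and lower numbers for a weaker effect. Compound 2 stands lowest of the two numbers, but its nearest neighbour is compound 1, whose value lies higher by an amount within the scatter, so the two cannot be told apart on these data. Among the compounds with values here, no step between measured compounds that differ in one place is available, so nothing is known here about how changes on the shared core move the read-out.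

Compound 3 `Nc1ccccc1NC(=O)c1ccc(CNc2nc(Cl)nc3c2ncn3C2CCCC2)cc1` differs from compound 2 in one place: cyclopentyl in place of benzyl on an aromatic nitrogen. Within the data shown here, since no single-change step is on record, the size of the effect in this assay is open; a step no larger than the scatter, in either direction, is expected. Compound 3 is therefore estimated at 42%, within 25% to 60%, a step of a number 4.4 percentage points lower from compound 2 to compound 3 (within the scatter) that is expected to be small.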

Compound 3, a percentage reported as inhibition, at one concentration (the size of the read-out at that concentration, not a potency): 57.4%
Estimate against measurement, compound 3: 15.4 percentage points below; low and high end bracket the measured number.
By their numbers in this assay, from the lowest: compounds 2, 1 and 3 (each within the scatter of the next, the first and the last beyond it).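

In this assay, within the data shown here, the first single-change step on record shows that this position on the aromatic nitrogen does influence the read-out: cyclopentyl in place of benzyl gives a number 11 percentage points higher from compound 2 to compound 3 (beyond the scatter) on the shared core. The benzyl group's six-membered aromatic ring is therefore not needed for inhibition at the one concentration tested, since a five-membered non-aromatic carbon ring with fewer heavy atoms serves at least as well in this pair. This rests on one pair of compounds, and nothing on record explains the step.

The compounds shown leave open whether the trend extends to a cyclohexyl ring, an open chain such as isopropyl or a ring carrying an amine. They also leave open whether the same change would act alike on the core of compound 1.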